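A few compounds are considered here, and "the series" means these few. Any claim that something is new, unique, unknown or untested is made for them only; others in the source may bear on it.

In an ADME assay on MT4 cells (Homo sapiens) for cytotoxicity, read by MTT assay, with a stated time of 4 days (on this read-out lower numbers stand for higher toxicity in this test and higher numbers for lower toxicity in this test), compound 1, with the structure `COc1cccc(/C=C/C(=O)c2cc(NC(C)=O)ccc2O)c1`, gives 40000 nM. Compound 2, `CC(=O)Nc1ccc(O)c(C(=O)/C=C/c2cccc(F)c2)c1`, differs from compound 1 by fluoro in place of methoxy on an aromatic carbon, and in this assay compound 2 gives 30100 nM. The step that this change made is a 1.3-fold lower number from compound 1 to compound 2 (0.12 log units; within the scatter), so the two numbers are not told apart by this test.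

Compound 3, `COc1ccccc1-c1cc(=O)c2cc(NC(C)=O)ccc2o1`, is built on a different core from compound 1; the difference between the two cores is not broken down here. In this assay compound 3 gives 226000 nM, the highest of the three numbers, and its gap to each of the other two lies beyond the scatter, which on this read-out means the lowest toxicity among the measured compounds.

Compound 4, `CC(=O)Nc1ccc2oc(-c3ccccc3F)cc(=O)c2c1`, has not yet been measured. It differs from compound 3 by fluoro in place of methoxy on an aromatic carbon. Among the compounds with values here, this is the same kind of change as the one from compound 1 to compound 2, though not the same: in compound 2 the fluoro sits meta to a large group, whereas in compound 4 it sits ortho to a large group. Because the earlier change gave a 1.3-fold lower number from compound 1 to compound 2 (0.12 log units; within the scatter), a step within the scatter, the corresponding step on the core of compound 3 is also expected to be small, estimated at a 1.1-fold lower number from compound 3 to compound 4 (0.05 log units; within the scatter). Compound 4 is therefore expected to give about 200000 nM in this assay, most likely between 100000 nM and 400000 nM.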

Compound 4, half-maximal cytotoxic concentration: 205000 nM
Compound 4: middle estimate off by 1.0-fold (0.01 log units), on the low side, within the range that was stated.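

In this assay, putting fluoro in place of methoxy on an aromatic carbon on the core of compound 3 gives a 1.1-fold lower number from compound 3 to compound 4 (0.04 log units; within the scatter), so this test cannot tell the two compounds apart. Set beside the same change on the core of compound 1, the new step agrees with the earlier one, and on these two cores the change carried over as a step too small for this test to resolve: the same change on two cores in this assay, a 1.3-fold lower number (0.12 log units; within the scatter) from compound 1 to compound 2 and a 1.1-fold lower number (0.04 log units; within the scatter) from compound 3 to compound 4, 1.2-fold (0.08 log units) apart, within the scatter of two such steps. This shows that on both cores the swap left the number within the usual scatter, even though in compound 4 the fluoro sits ortho to a large group, but it rests on just two pairs and does not show that the step would stay this small on a third core or in a different test, nor does it explain why either step is small.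

The compounds shown leave open what an amine or a carboxylic acid on this same aromatic carbon would do to the number on either core. They also leave open whether a longer chain, such as butoxy, would stay as close to methoxy and fluoro as these two groups stay to each other.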